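The source may report more compounds than this note shows. Statements on the series, on what has been measured and on what is new or still open speak of the compounds shown alone.

Measured so far:
- Compound 1 `Cc1ccc(C(=O)c2cc(F)c(OCC(=O)NNC(=O)c3ccc(=O)oc3)c(Cl)c2)cc1`: 21400 nM
- Compound 2 `Cc1ccc(C(=O)c2cc(F)c(OCC(=O)NNC(=O)c3cn(C)cn3)c(Cl)c2)cc1`: 9100 nM

Going by the values given here, in a functional assay on A549 cells (Homo sapiens) for cytotoxicity, read by LDH release, with a stated time of 48 h (on this read-out higher numbers stand for weaker inhibition and lower numbers for stronger inhibition), compound 1 gives 21400 nM, the higher of the only two numbers available. Compound 3 `O=C(COc1c(F)cc(C(=O)c2ccc(Cl)cc2)cc1Cl)NNC(=O)c1ccc(=O)oc1` has not yet been measured. It differs from compound 1 by one small swap: chloro in place of methyl on an aromatic carbon, giving 4-chlorophenyl in place of 4-methylphenyl.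

Among the compounds with values here, only one measured step exists, a 2.4-fold lower number from compound 1 to compound 2 (0.37 log units; beyond the scatter), and it is modest. That step replaces a ring group on a carbonyl carbon, elsewhere in the molecule, so it bears only indirectly on this swap. It does show that a larger change moved the number only modestly. Within the data shown here, no measured compound changes the methyl itself, so the data suggest no direction, and no step beyond the scatter is expected.

The expected step is a 1.2-fold lower number from compound 1 to compound 3 (0.08 log units; within the scatter). For compound 3 the estimated value is 18000 nM, within an expected range of 8000 nM to 40000 nM.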

Compound 3, half-maximal inhibitory concentration: 84900 nM
The estimate for compound 3 lay 4.7-fold (0.67 log units) below the measured number, outside the stated range (above it).
By their numbers in this assay, from the lowest: compound 2; then compound 1; then compound 3.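

The 4-methylphenyl ring of the core, at the carbon para to a large group, turns out to be sensitive: chloro in place of methyl gives a 4.0-fold higher number from compound 1 to compound 3 (0.60 log units; beyond the scatter) in this assay even though one heavy atom simply replaces another and the count of hydrogen-bond donors and acceptors stays the same. A single-atom change here is therefore enough to move the number beyond the scatter, as the much larger ring exchange on the carbonyl carbon also did with a 2.4-fold lower number from compound 1 to compound 2 (0.37 log units; beyond the scatter) in the opposite direction. Nothing measured here explains what lies behind the higher number for chloro.

As far as these compounds go, only methyl and chloro are compared at this position, so it remains open whether a fluoro, a methoxy or an amine there would give a lower or a higher number. From the compounds shown here alone, it is also open whether chloro in place of methyl would shift compound 2 in the same way.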